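The source may hold more compounds than are shown below. What is called first, only, known or untested is meant among the compounds shown, and "the series" means these compounds.

Compound 1 `O=C(CCCCC1CCSS1)Nc1ccc(Br)cn1`: 4.27%
Compound 2 `O=C(CCCCC1CCSS1)Nc1cccc2ccccc12`: 6.95%
Compound 3 `O=C(CCCCC(S)CCS)Nc1ccc(Cl)cc1`: 2.81%

In a functional assay on HO8910 cells (Homo sapiens) for inhibition, read by MTT assay, with a stated time of 24 h, tested at 1 ug/mL (a lower number here means less inhibition of growth, a higher number more inhibition of growth at the concentration tested), compound 3 gives 2.81%, which lies within the scatter of both compound 1 and compound 2, so the three numbers cannot be told apart. Compound 4 `COc1ccc(NC(=O)CCCCC(S)CCS)cc1` has not yet been measured. It differs from compound 3 as follows: methoxy in place of chloro on an aromatic carbon, para to a large group. Within the data shown here, no measured pair shows what a single such change does, so no step beyond the scatter is expected. The expected step of a number 1.2 percentage points higher from compound 3 to compound 4 (within the scatter) stays within the scatter. For compound 4 the estimated value is 4%, with an expected range of 0% to 11%.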

Compound 4, percent growth inhibition at one concentration: 1.79%
For compound 4 the middle estimate is 2.2 percentage points above the measured one; low and high end bracket the measured number.
By their numbers in this assay, from the lowest: compounds 4, 3, 1 and 2 (each within the scatter of the next).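

In this assay, among these compounds, the change to methoxy in place of chloro on an aromatic carbon, para to a large group, gives a number 1 percentage points lower from compound 3 to compound 4 (within the scatter) and so provides the first single change that can be read. At this position, the two groups cannot be told apart at the concentration tested. No evidence on any property bears on this result, so nothing can be said of what lies behind it. As far as these compounds go, it remains open whether an amine or a carboxylic acid at this position, or a longer chain on the amide carbonyl, would give a number beyond the scatter of compound 3.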